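This account rests on a few compounds, and the source may have more. Where it says the series, first, only, none or still open, it means among the compounds named here.

Measured compounds:
- compound 1, `CS(=O)(=O)c1ccc(-c2cnc3[nH]cc(-c4nnc(-c5ccccc5)o4)c(=O)c3c2)cc1`: 15.7%
- compound 2, `CS(=O)(=O)c1ccc(-c2cnc3[nH]cc(-c4nnc(-c5cccnc5)o4)c(=O)c3c2)cc1`: 14.7%
- compound 3, `O=c1c(-c2nnc(-c3ccc(Cl)cc3)o2)c[nH]c2ncc(-c3cccnc3)cc12`: 11.8%

All three were run in a functional assay on HCT-116 cells (Homo sapiens) for inhibition, read by MTT assay, with a stated time of 24 h, tested at 10 uM; a higher number here means more inhibition of growth at the concentration tested, a lower number less inhibition of growth. Compound 1 and compound 2 differ in one place, (phenyl in place of pyridin-3-yl on an aromatic carbon), and that step is a number 1 percentage points higher from compound 2 to compound 1 (within the scatter). Compound 3 and compound 2 share no single counted difference; how the two cores differ is not broken down here. The values of compound 3 and compound 2 lie within the usual scatter of each other.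

Compound 4, `O=c1c(-c2nnc(-c3ccc(Cl)cc3)o2)c[nH]c2ncc(-c3ccccc3)cc12`, is not yet measured. It differs from compound 3 by phenyl in place of pyridin-3-yl on an aromatic carbon. This is the same kind of change as that from compound 2 to compound 1, but not the same: there the phenyl entered on an aromatic carbon of a five-membered aromatic ring with 2 nitrogen and 1 oxygen, next to the ring nitrogen and next to the ring oxygen, whereas here it enters on an aromatic carbon of a six-membered aromatic ring with 1 nitrogen, part of a fused system of two rings, two atoms from the ring nitrogen. Since the earlier step is a number 1 percentage points higher from compound 2 to compound 1 (within the scatter), the step from compound 3 to compound 4 is expected to be small as well, a number 1.2 percentage points higher from compound 3 to compound 4 (within the scatter). Compound 4 is thus estimated at 13%, between 3% and 23%, in this assay.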

Compound 4, percent growth inhibition at one concentration: 21.6%
For compound 4 the middle estimate is 8.6 percentage points below the measured one, and the stated range covers the measured number.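

Replacing pyridin-3-yl with phenyl on the core of compound 3 gives, in this assay, a number 9.8 percentage points higher from compound 3 to compound 4 (within the scatter). Set beside the same change on the other site, this step does not differ from the earlier one: the same change on two cores in this assay, a number 1 percentage points higher (within the scatter) from compound 2 to compound 1 and a number 9.8 percentage points higher (within the scatter) from compound 3 to compound 4, 8.8 percentage points apart, within the scatter of two such steps. The two pairs therefore show no detectable dependence of this change on where it is made, but both steps lie within the scatter, so they do not show that the change has a real effect at either site or that it would carry to a further core.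

Open, on these data alone, is whether a basic amine or a carboxylic acid in place of the phenyl or pyridin-3-yl would move growth inhibition beyond the scatter. Also open, as far as these compounds go, is how compounds behave at other concentrations.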